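A few compounds are considered here, and "the series" means these few. Any claim that something is new, unique, unknown or untested is made for them only; others in the source may bear on it.

Working notes on the series. Three measured compounds share one core and differ only in the group attached to the five-membered aromatic ring with 1 sulfur: compound 1 `COc1cc(C(=O)c2sc(-c3ccc(F)cc3)cc2N)cc(OC)c1OC`, compound 2 `COc1cc(C(=O)c2sc(-c3ccc(Cl)c(Cl)c3)cc2N)cc(OC)c1OC` and compound 3 `COc1cc(C(=O)c2sc(-c3ccc([N+](=O)[O-])cc3)cc2N)cc(OC)c1OC`. In a functional assay on CCRF-CEM cells (Homo sapiens) for antiproliferative activity (a higher number here means a weaker inhibitor, a lower number a stronger inhibitor), compound 1 gives 15 nM. Compound 2 gives 290 nM in this assay, and compound 3 gives 99 nM. Compound 2 stands at the highest number of the three, compound 3 nearest and compound 1 furthest: a 19-fold higher number from compound 1 to compound 2 (1.29 log units; beyond the scatter) and a 2.9-fold lower number from compound 2 to compound 3 (0.47 log units; beyond the scatter).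

Compound 4 `COc1cc(C(=O)c2sc(-c3ccc(I)cc3)cc2N)cc(OC)c1OC` is not yet measured. The change from compound 2 is 4-iodophenyl in place of 3,4-dichlorophenyl on an aromatic carbon. The step of a 19-fold higher number from compound 1 to compound 2 (1.29 log units; beyond the scatter) bears most on it, since the 3,4-dichlorophenyl that entered there now leaves again for a 4-iodophenyl, so that step read backwards points to a lower number; a 2.9-fold lower number from compound 2 to compound 3 (0.47 log units; beyond the scatter) likewise showed a lower number when 3,4-dichlorophenyl left. A clear drop is expected, though nothing measured shows whether 4-iodophenyl reaches the level of 4-fluorophenyl in compound 1. Compound 4 is therefore estimated at 40 nM (range 12 nM to 130 nM), an expected step of a 7.3-fold lower number from compound 2 to compound 4 (0.86 log units; beyond the scatter).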

Compound 4, half-maximal inhibitory concentration: 150 nM
Compound 4: middle estimate off by 3.8-fold (0.57 log units), on the low side, and the stated range ends below it.
By their numbers in this assay, from the lowest: compound 1; then compounds 3, 4 and 2 (each within the scatter of the next, the first and the last beyond it).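

Replacing 3,4-dichlorophenyl with 4-iodophenyl on this carbon next to the ring sulfur gives a 1.9-fold lower number from compound 2 to compound 4 (0.29 log units; within the scatter) in this assay, so losing the 3,4-dichlorophenyl does not by itself restore the level of compound 1. Iodo in place of nitro gives a 1.5-fold higher number from compound 3 to compound 4 (0.18 log units; within the scatter) and iodo in place of fluoro gives a 10-fold higher number from compound 1 to compound 4 (1.00 log units; beyond the scatter), which makes 4-fluorophenyl the only group among the four whose compound stands apart from all the others, with compounds 2, 3 and 4 each at a higher number than compound 1. No measurement at hand accounts for this separation.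

The compounds shown leave open whether the low number of compound 1 is particular to fluoro, or also holds for chloro or bromo in place of the iodo of compound 4. Also open, on these data alone, is how an unsubstituted phenyl, or a phenyl carrying an amine or a carboxylic acid, would compare on this carbon.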